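This account rests on a few compounds, and the source may have more. Where it says the series, first, only, none or still open, it means among the compounds named here.

Compound 1 `FC(F)(F)c1ccc(-c2nn(-c3ccccc3)cc2-c2nc3ccccc3[nH]2)cc1`: 3620 nM
Compound 2 `Cc1ccc(-c2nn(-c3ccccc3)cc2-c2nc3ccccc3n2S(=O)(=O)c2ccccc2)cc1`: 760 nM
Compound 3 `Cc1ccc(-c2nn(-c3ccccc3)cc2-c2nc3ccccc3n2S(=O)(=O)c2cc(C)ccc2C)cc1`: 270 nM

All three numbers come from a functional assay on A549 cells (Homo sapiens) for antiproliferative activity, read by MTT assay, with a stated time of 24 h; a higher number here means a weaker inhibitor, a lower number a stronger inhibitor. Compound 3 gives the lowest number of the three; compound 2 stands nearest to it and compound 1 furthest, both gaps beyond the scatter. The step to compound 4 `Cc1ccc(-c2nn(-c3ccccc3)cc2-c2nc3ccccc3n2S(=O)(=O)c2ccc(Cl)cc2)cc1` is 4-chlorophenyl in place of 2,5-dimethylphenyl on a sulfonyl sulfur. Within the data shown here, the only measured change on this sulfonyl sulfur is a 2.8-fold lower number from compound 2 to compound 3 (0.45 log units; beyond the scatter), and no measured compound carries a chlorine there. As compound 4 keeps a group on the ring on that sulfur, where compound 2 has none, the expected step of a 1.5-fold higher number from compound 3 to compound 4 (0.17 log units; within the scatter) is small, toward a somewhat higher number, and may fall within the scatter. Compound 4 is therefore estimated at 400 nM, with a range from 180 nM to 900 nM.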

Compound 4, half-maximal inhibitory concentration: 3550 nM
Estimate against measurement, compound 4: 8.9-fold (0.95 log units) below; measured number above the stated range.
By their numbers in this assay, from the lowest: compound 3; then compound 2; then compounds 4 and 1 (each within the scatter of the next).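

Among these compounds, a group on the ring on this sulfonyl sulfur can weaken as well as strengthen: the earlier compounds showed only a gain, yet a 13-fold higher number from compound 3 to compound 4 (1.12 log units; beyond the scatter) comes with 4-chlorophenyl in place of 2,5-dimethylphenyl. Chloro in place of hydrogen alone gives a 4.7-fold higher number from compound 2 to compound 4 (0.67 log units; beyond the scatter) against the plain phenyl, so the direction depends on which group is added. Nothing measured here accounts for this difference between the groups.

Going by these compounds, whether a single methyl, a methoxy or an amine on this ring would follow the chloro or the two methyl groups remains open.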